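Aryl swap on the shared core: dichloro, trifluoromethyl, dimethyl

The source may report more compounds than this note shows. Statements on the series, on what has been measured and on what is new or still open speak of the compounds shown alone.

Among the compounds with values here, compound 2 `CC(C)c1onc(-c2ccccc2C(F)(F)F)c1COc1ccc(CCCC(=O)O)cc1` gives 4400 nM in an assay on HEK-293T cells for activation of Bile acid receptor (Homo sapiens), read by a luciferase reporter, with a stated time of 14 h (on this read-out higher numbers stand for an effect only at larger amounts of compound and lower numbers for an effect already at smaller amounts), the lower of the two numbers so far; compound 1 `CC(C)c1onc(-c2c(Cl)cccc2Cl)c1COc1ccc(CCCC(=O)O)cc1` gives 6000 nM, and the step of a 1.4-fold lower number from compound 1 to compound 2 (0.13 log units; within the scatter) stays within the scatter. Compound 3 `Cc1cccc(C)c1-c1noc(C(C)C)c1COc1ccc(CCCC(=O)O)cc1` carries 2,6-dimethylphenyl in place of 2-(trifluoromethyl)phenyl on an aromatic carbon. Within the data shown here, the only step that bears on this aryl position is the one from compound 1 to compound 2, and it was within the scatter, so no step beyond the scatter is expected in this assay for compound 3, with a 1.1-fold higher number from compound 2 to compound 3 (0.06 log units; within the scatter) as the expected change. Compound 3 is estimated at 5000 nM, in the range 2000 nM to 12000 nM.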

Compound 3, half-maximal effective concentration: 7700 nM
Compound 3: the middle estimate sits 1.5-fold (0.19 log units) below what was measured; measured number inside the range.
By their numbers in this assay, from the lowest: compounds 2, 1 and 3 (each within the scatter of the next).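

In this assay, 2,6-dimethylphenyl stays within the scatter of both other aryl groups at this position (a 1.8-fold higher number from compound 2 to compound 3 (0.24 log units; within the scatter); a 1.3-fold higher number from compound 1 to compound 3 (0.11 log units; within the scatter)). Chlorine and fluorine atoms are therefore not required on this aryl group for the number to stay in this range, since a group of carbon only reads alike. Nothing available explains why these three groups read alike.

Still open, on these data alone, is whether a methoxy group or an amine on this phenyl moves the number beyond the scatter. The same question stands for a longer chain carrying the carboxylic acid.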